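The compounds below may be only part of what the source reports. "The series", "measured", "known", "first", "only" and "open" are said of these compounds alone.

Compound 1 `Cn1c(=O)c(S(=O)(=O)c2ccc(F)cc2[N+](=O)[O-])cc2cnc(Nc3ccc4[nH]ccc4c3)nc21`: 900 nM
Compound 2 `Cn1c(=O)c(S(=O)(=O)c2ccc(F)cc2)cc2cnc(Nc3cccc4[nH]ccc34)nc21`: 750 nM
Compound 3 `Cc1ccc(S(=O)(=O)c2cc3cnc(Nc4ccc5ncccc5c4)nc3n(C)c2=O)cc1`: 10000 nM

All three compounds share one core and were tested in a functional assay on K562 cells (Homo sapiens) for inhibition, read by trypan blue exclusion, with a stated time of 72 h; a higher number here means a weaker inhibitor, a lower number a stronger inhibitor. Among the three numbers, compound 1 stands second highest. Its nearest neighbour is compound 2, which gives 750 nM, while compound 1 gives 900 nM, a gap within the scatter, so no order between the two can be read. For the measured compounds named here, compound 3 stands furthest away with 10000 nM, a gap beyond the scatter, but compound 3 differs from compound 1 in more than one place and no single step between measured compounds is available here.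

The unmeasured compound 4 `Cn1c(=O)c(S(=O)(=O)c2ccc(Cl)cc2Cl)cc2cnc(Nc3ccc4[nH]ccc4c3)nc21` differs from compound 1 in one place: 2,4-dichlorophenyl in place of 4-fluoro-2-nitrophenyl on a sulfonyl sulfur. The rest of compound 1 is kept. As a guide, compound 1 at 900 nM and compound 2 at 750 nM carry different groups on the sulfonyl sulfur yet sit within the scatter of each other. On that ground the expected step is a 1.1-fold higher number from compound 1 to compound 4 (0.05 log units; within the scatter), none beyond the scatter in either direction. Compound 4 is therefore estimated at 1000 nM, with a range from 300 nM to 3500 nM.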

Compound 4, half-maximal inhibitory concentration: 1000 nM
For compound 4 middle estimate and measured number coincide at the digits printed; the measured number falls inside the stated range.
By their numbers in this assay, from the lowest: compounds 2, 1 and 4 (each within the scatter of the next); then compound 3.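

For the compounds shown here, replacing 4-fluoro-2-nitrophenyl with 2,4-dichlorophenyl on a sulfonyl sulfur gives a 1.1-fold higher number from compound 1 to compound 4 (0.05 log units; within the scatter) in this assay and provides the first single-place comparison at this position. The earlier compounds shown here carried different groups there but also differed elsewhere, whereas this pair keeps the rest of compound 1 and shows that these two groups cannot be told apart in this read-out, even though the group that leaves has 2 hydrogen-bond acceptors and the group that enters has none. No measurement shown offers a reason for this result.

As far as these compounds go, the step covers only these two substituted phenyl groups, so it remains open whether the same holds for a group of another kind on the sulfonyl sulfur, such as a carboxylic acid-bearing phenyl, a morpholine or a longer alkyl chain. Compound 3 has no single-place partner among the compounds shown, so what sets its number apart from the others also remains open.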